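The source may hold more compounds than are shown below. What is called first, only, known or untested is meant among the compounds shown, and "the series" means these compounds.

The series shares the core of compound 1 `Cc1ccc(S(=O)(=O)N[C@@H](CC(=O)NC(C)(C)C)C(=O)NCCNS(=O)(=O)c2ccccc2)cc1`, which in an ADME assay on HepG2 cells (Homo sapiens) for cytotoxicity (a higher number here means that more compound is needed for the effect, a lower number that less compound is needed), returns only a limit of the assay and not a number: compound 1 reads > 11000 nM. Compound 2 `Cc1ccc(S(=O)(=O)N[C@@H](CC(=O)NC(C)(C)C)C(=O)NCCNC(=O)c2cccc(C(F)(F)F)c2)cc1` carries (3-(trifluoromethyl)phenyl)carbonyl in place of phenylsulfonyl on an amine nitrogen; in this assay compound 2 also stops at a limit, > 11000 nM. Compound 3 `Cc1ccc(S(=O)(=O)N[C@@H](CC(=O)NC(C)(C)C)C(=O)NCCNC(=O)c2ccc(Cl)cc2)cc1` carries (4-chlorophenyl)carbonyl on that amine nitrogen, and compound 3 likewise sits at a limit, > 11000 nM. All three values rest on one limit (the limit of > 11000 nM in this assay, at which 3 of the 3 values shown sit), so the steps a step that the two limits leave unreadable from compound 1 to compound 2, a step that the two limits leave unreadable from compound 1 to compound 3 and a step that the two limits leave unreadable from compound 2 to compound 3 cannot be sized.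

Compound 4 `COc1cccc(C(=O)NCCNC(=O)[C@H](CC(=O)NC(C)(C)C)NS(=O)(=O)c2ccc(C)cc2)c1` is not yet measured in this assay. It differs from compound 1 by (3-methoxyphenyl)carbonyl in place of phenylsulfonyl on an amine nitrogen. The measured steps that bear on this change are the two other exchanges of phenylsulfonyl for an aryl carbonyl on the same amine nitrogen, a step that the two limits leave unreadable from compound 1 to compound 2 and a step that the two limits leave unreadable from compound 1 to compound 3, and neither is readable in size. Nothing among them shows a step beyond the scatter, so for compound 4 a step that the limit leaves unreadable from compound 1 to compound 4 is expected, most likely ending again at the limit. The value expected for compound 4 is 20000 nM, with a range from 11000 nM to 60000 nM.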

Compound 4, half-maximal effective concentration: > 11000 nM
Compound 4 was reported as a limit; the forecaster's own chance of this, stated with the estimate: 85%; the middle value lies beyond the limit too.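

In this assay compound 4 gives > 11000 nM, a limit of the assay and not a number. The steps joining compound 4 to compound 1, compound 2 and compound 3 therefore cannot be read: the limit of > 11000 nM in this assay, at which 4 of the 4 values shown sit. The compounds shown leave open whether the groups on that amine nitrogen differ at all in this assay.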